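The source may report more compounds than this note shows. Statements on the series, on what has been measured and on what is new or still open speak of the compounds shown alone.

The measured compounds in a functional assay on the whole organism (strain Wistar) for inhibition, with Rattus norvegicus as the target, read by paw edema, with stated times of 60 min and 4 h, at a dose of 100 mg/kg by the oral route (on this read-out lower numbers stand for less inhibition and higher numbers for more inhibition at the one dose given (going by the name of the read-out)), are:

Compound 1 `CCNC(=O)CC1CCc2cc(OC)c(OC)cc21` — 26.6%
Compound 2 `COc1cc2c(cc1OC)C(CC(=O)NC(C)C)CC2` — 39.1%
Compound 3 `COc1cc2c(cc1OC)C(CC(=O)NC1CCCCC1)CC2` — 50%

Compound 3 stands highest of the three in this assay; its nearest neighbour is compound 2, which lies beyond the scatter below it, and compound 1 lies furthest below. The step from compound 3 leads to compound 4 `COc1cc2c(cc1OC)C(CC(=O)NCCO)CC2`, which differs in one place: 2-hydroxyethyl in place of cyclohexyl on an amide-type nitrogen.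

The measured steps that bear on this change all concern the group on the amide-type nitrogen. From the ethyl of compound 1 to the cyclohexyl of compound 3 the number rose by a number 23.4 percentage points higher from compound 1 to compound 3 (beyond the scatter), and from the isopropyl of compound 2 to the cyclohexyl of compound 3 by a number 10.9 percentage points higher from compound 2 to compound 3 (beyond the scatter). Within these three compounds, every move to a larger group on that nitrogen raised inhibition in this assay. Among the compounds with values here, the 2-hydroxyethyl group entering compound 4 is closer in size to the ethyl of compound 1 than to the cyclohexyl it replaces, and nothing among the measured compounds shows the effect of a hydroxyl on that chain. The step from compound 3 to compound 4 is therefore expected to be downward in this assay, roughly a number 20 percentage points lower from compound 3 to compound 4 (beyond the scatter), undoing most of the gain seen with cyclohexyl. Compound 4 is estimated to give 30% in this assay, with a range from 15% to 45%.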

Compound 4, a percentage reported as inhibition, in the whole organism at one dose (the size of the read-out at that dose, not a potency): 9.37%
Beside the measured number, compound 4's estimate is 20.6 percentage points above it; the measured number lies below the stated range.
By their numbers in this assay, from the lowest: compound 4; then compound 1; then compound 2; then compound 3.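

In this assay, the chain on the amide-type nitrogen now shows an effect that does not follow group size alone: hydroxy in place of hydrogen on the ethyl chain gives a number 17.2 percentage points lower from compound 1 to compound 4 (beyond the scatter). Replacing the larger groups with 2-hydroxyethyl gives a number 40.6 percentage points lower from compound 3 to compound 4 (beyond the scatter) and a number 29.7 percentage points lower from compound 2 to compound 4 (beyond the scatter), which places compound 4 below all three earlier compounds and makes it the exception to the rise in inhibition seen from ethyl through isopropyl to cyclohexyl. No measured property of these compounds is available to explain the drop that hydroxy brings to this position.

The compounds shown leave open whether the fall belongs to the free hydroxyl itself or would also follow a methoxy, a primary amine or a carboxylic acid at the end of the same chain, and whether a longer chain such as 3-hydroxypropyl would recover any inhibition. They also leave open whether a hydroxyl carried on the cyclohexyl ring would cost as much as it does on the ethyl chain, and how any of these groups would compare at doses other than the single one given.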